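The source may hold more compounds than are shown below. What is called first, only, known or untested is meant among the compounds shown, and "the series" means these compounds.

Compound 1 `COc1ncc(-c2ccc3c(c2)N(CCCn2ccccc2=O)C(=O)CO3)cc1NS(=O)(=O)c1ccc(F)cc1F` gives 12400 nM
Compound 2 `CCCCS(=O)(=O)Nc1cc(-c2ccc3c(c2)N(CCCN(CC)CC)C(=O)CO3)cnc1OC` gives 13800 nM

Both numbers come from a functional assay on MDA-MB-231 cells (Homo sapiens) for antiproliferative activity, read by sulforhodamine B assay, with a stated time of 72 h (on this read-out lower numbers stand for stronger inhibition and higher numbers for weaker inhibition), and compound 2 stands within the usual scatter of compound 1. Compound 3 `CCCCS(=O)(=O)Nc1cc(-c2ccc3c(c2)N(CCC(=O)N2CCOCC2)C(=O)CO3)cnc1OC` carries (morpholin-4-yl)carbonyl in place of (diethylamino)methyl on a saturated chain carbon, two bonds along the chain from an amide-type nitrogen in a ring. For the measured compounds named here, no measured pair shows what this change does, so the expectation rests on compound 2 (13800 nM) and no shift beyond the scatter is foreseen. The estimated change (a 1.2-fold lower number from compound 2 to compound 3 (0.06 log units; within the scatter)) stays within that scatter. Compound 3 is expected at 12000 nM (range 4000 nM to 35000 nM).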

Compound 3, half-maximal inhibitory concentration: 43800 nM
Compound 3: the middle estimate sits 3.7-fold (0.56 log units) below what was measured; measured number outside the range, above it.
By their numbers in this assay, from the lowest: compounds 1 and 2 (each within the scatter of the next); then compound 3.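

At this position, on a saturated chain carbon two bonds along the chain from an amide-type nitrogen in a ring, the end of the side chain does affect this assay: placing (morpholin-4-yl)carbonyl where (diethylamino)methyl stood gives a 3.2-fold higher number from compound 2 to compound 3 (0.50 log units; beyond the scatter), a modest weakening beyond the scatter. Nothing available explains this shift.

The change brings in the ring and the carbonyl together, leaving open which of them accounts for the weakening. A (morpholin-4-yl)methyl group, an amine without the carbonyl, would separate the two.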